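Cyclopropyl for tert-Butyl on a Liver-Cell Toxicity Read-out

The compounds below may be only part of what the source reports. "The series", "measured", "known", "first", "only" and "open" are said of these compounds alone.

Compound 1 `CC(C)(C)CCn1nc(-c2cccs2)c(O)c(C2=NS(=O)(=O)c3cc(NS(C)(=O)=O)ccc3N2)c1=O` was tested in an ADME assay on Huh-7 cells (Homo sapiens) for cytotoxicity, with a stated time of 72 h; on this read-out higher numbers stand for lower toxicity in this test and lower numbers for higher toxicity in this test. For compound 1 the result is a limit, > 1000 nM. Compound 2 `CS(=O)(=O)Nc1ccc2c(c1)S(=O)(=O)N=C(c1c(O)c(-c3cccs3)nn(CCC3CC3)c1=O)N2` carries cyclopropyl in place of tert-butyl on a saturated chain carbon, two bonds along the chain from an aromatic nitrogen. For compound 2 the result is also a limit, > 33000 nM. The step that the two limits leave unreadable from compound 1 to compound 2 therefore cannot be sized. Compound 3 `CC(C)(C)Cn1nc(-c2cccs2)c(O)c(C2=NS(=O)(=O)c3cc(NS(C)(=O)=O)ccc3N2)c1=O` differs from compound 1 by tert-butyl in place of neopentyl on a saturated chain carbon bound to an aromatic nitrogen. For compound 3 the result is again a limit, > 1000 nM. Compound 4 `CS(=O)(=O)Nc1ccc2c(c1)S(=O)(=O)N=C(c1c(O)c(-c3cccs3)nn(CC3CC3)c1=O)N2` is not yet measured; it differs from compound 3 by cyclopropyl in place of tert-butyl on a saturated chain carbon bound to an aromatic nitrogen. This is the same kind of change as that from compound 1 to compound 2, but the place differs: there the carbon was two bonds along the chain from an aromatic nitrogen, here it is bound to an aromatic nitrogen. Among the measured compounds shown here, because every value so far sits at a limit (the limit of > 1000 nM in this assay, at which 2 of the 3 values shown sit, and (the limit of > 33000 nM in this assay, at which 1 of the 3 values shown sits)), no size can be read from the measured pairs. Compound 4 is expected to show a step that the limit leaves unreadable from compound 3 to compound 4, most likely again reported only as a limit. The estimate for compound 4 is 40000 nM.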

Compound 4, half-maximal cytotoxic concentration: > 1000 nM
Compound 4: no number, only a limit; the forecaster's own chance of this, stated with the estimate: 85%; the middle value does not contradict the limit.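

Compound 4 is reported only as a limit, > 1000 nM. Among the compounds shown here, compound 1, compound 2 and compound 3 are limits too, and no step from any of them to compound 4 can be read. The compounds shown leave open at what concentration any of them harms these cells, and whether changing the chain group alters that.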